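From a hydroxycarbamoyl chain to a methylcarbamoyl chain

The compounds below may be only part of what the source reports. "The series", "measured", "known", "first", "only" and "open" are said of these compounds alone.

Measured in a functional assay on Bel-7402 cells (Homo sapiens) for inhibition, read by MTT assay, with a stated time of 72 h; on this read-out higher numbers stand for weaker inhibition and lower numbers for stronger inhibition:
- compound 1 `Nc1nc2cc(-c3nn(CCCCCCCCCC(=O)NO)c4ncnc(N)c34)ccc2o1` gives > 50000 nM (a limit)
- compound 2 `Nc1nc2cc(-c3nn(CCCCC(=O)NO)c4ncnc(N)c34)ccc2o1` gives 2400 nM
- compound 3 `Nc1nc2cc(-c3nn(CCCCCCCCC(=O)NO)c4ncnc(N)c34)ccc2o1` gives > 100000 nM (a limit)

Compound 3 gives only a limit, > 100000 nM. Compound 1 also gives only a limit, > 50000 nM, and a step that the two limits leave unreadable from compound 1 to compound 3. Compound 2 alone gives a number, 2400 nM.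

Compound 4 `CNC(=O)CCCCCCCn1nc(-c2ccc3oc(N)nc3c2)c2c(N)ncnc21` has not yet been measured. It differs from compound 3 as follows: methylcarbamoyl in place of (hydroxycarbamoyl)methyl on a saturated chain carbon, seven bonds along the chain from an aromatic nitrogen. Methylcarbamoyl stands in place of (hydroxycarbamoyl)methyl on a saturated chain carbon, seven bonds along the chain from an aromatic nitrogen.

Among the compounds with values here, no measured step makes this exchange. The nearest evidence concerns the chain alone, and both readable steps are large: an at least 20-fold lower number from compound 1 to compound 2 (1.31 log units; beyond the scatter) and an at least 41-fold higher number from compound 2 to compound 3 (1.61 log units; beyond the scatter). The chain of compound 4 is closer to that of compound 3 than to that of compound 2, so no gain in this assay is expected. The expected step is a number no higher from compound 3 to compound 4 (the limit leaves the size open), and none beyond the scatter is expected. Compound 4 is estimated at 100000 nM, with an expected range from 30000 nM to 300000 nM.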

Compound 4, half-maximal inhibitory concentration: 13200 nM
Beside the measured number, compound 4's estimate is 7.6-fold (0.88 log units) above it; the measured number lies below the stated range.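

In this assay, the methylcarbamoyl end, on a saturated chain carbon seven bonds along the chain from an aromatic nitrogen, gives a readable number, with an at least 7.5-fold lower number from compound 3 to compound 4 (0.87 log units; beyond the scatter) and an at least 3.7-fold lower number from compound 1 to compound 4 (0.57 log units; beyond the scatter). A hydroxycarbamoyl end is therefore not required for a readable number in this series, although the shorter hydroxycarbamoyl chain still leads, with a 5.5-fold higher number from compound 2 to compound 4 (0.74 log units; beyond the scatter). The step between the two limit compounds cannot be read, and the value of compound 3 is a limit: the limit of > 100000 nM in this assay, at which 1 of the 4 values shown sits.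

As far as these compounds go, the true size of the steps starting from compound 1 stays open, since its value is also a limit: the limit of > 50000 nM in this assay, at which 1 of the 4 values shown sits A carboxylic acid or an amine at the end of this chain, or a methylcarbamoyl end on a shorter chain, would be needed to separate the effect of the chain from that of its end group.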